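The source may report more compounds than this note shows. Statements on the series, on what has been measured and on what is new or still open speak of the compounds shown alone.

Measured compounds:
Compound 1, `COc1ccc2oc(CSC(=S)N3CCOCC3)cc(=O)c2c1`: 3400 nM
Compound 2, `COc1ccc2occ(CSC(=S)N3CCCCC3)c(=O)c2c1`: 930 nM
Compound 3, `O=c1cc(CSC(=S)N2CCOCC2)oc2ccccc12`: 22200 nM

Of the compounds shown here, three have been tested in a functional assay on MDA-MB-435S cells (Homo sapiens) for antiproliferative activity, read by MTT assay, with a stated time of 72 h; on this read-out lower numbers stand for stronger inhibition and higher numbers for weaker inhibition. Compound 2 gives the lowest number, 930 nM. Compound 1 gives 3400 nM. Compound 3 gives 22200 nM. Compound 1 and compound 3 differ in one place only: hydrogen in place of methoxy on an aromatic carbon. This change produced a 6.5-fold higher number from compound 1 to compound 3 (0.81 log units; beyond the scatter). The difference between the core of compound 1 and the core of compound 2 is not broken down here.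

Compound 4, `O=c1c(CSC(=S)N2CCCCC2)coc2ccccc12`, has not yet been measured in this assay. It stands to compound 2 as compound 3 stands to compound 1: hydrogen in place of methoxy on an aromatic carbon. The place of the change is described in the same words in both cases, so it is the same change. Because the same change already produced a 6.5-fold higher number from compound 1 to compound 3 (0.81 log units; beyond the scatter), the step from compound 2 to compound 4 is expected to be of similar size, a 6.5-fold higher number from compound 2 to compound 4 (0.81 log units; beyond the scatter). This expectation rests on a single measured pair, so it is uncertain. Compound 4 is estimated at 6000 nM, with a likely range from 2500 nM to 15000 nM.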

Compound 4, half-maximal inhibitory concentration: 470 nM
The estimate for compound 4 lay 13-fold (1.11 log units) above the measured number; measured number outside the range, below it.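

In this assay the swap of methoxy for hydrogen on the core of compound 2 gives a 2.0-fold lower number from compound 2 to compound 4 (0.30 log units; within the scatter), so on this core the two compounds cannot be told apart. This change therefore cannot be treated as a fixed increment that carries from one core to another in this series, since the loss seen on the first pair does not appear on the second: the same change on two cores in this assay, a 6.5-fold higher number (0.81 log units; beyond the scatter) from compound 1 to compound 3 and a 2.0-fold lower number (0.30 log units; within the scatter) from compound 2 to compound 4, 13-fold (1.11 log units) apart, beyond the scatter of two such steps

Among the compounds shown here, this does not show why the two steps differ, and with only two pairs it gives no rule for predicting the step on a further core, as the two pairs differ from each other in more than one place.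

On these data alone, it remains open which of those differences sets the size of the step. As far as these compounds go, it also remains open how other groups on the same aromatic carbon, such as a fluorine atom, a hydroxy group or a longer ethoxy chain, would behave on each core.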